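A few compounds are considered here, and "the series" means these few. Any claim that something is new, unique, unknown or untested is made for them only; others in the source may bear on it.

Working notes on a small set of nucleoside-like analogues sharing one fused core. The read-out throughout is a functional assay (Homo sapiens) for inhibition of Nucleic Acid, tested at 100 uM; a lower number here means less inhibition, a higher number more inhibition at the concentration tested (going by the name of the read-out). Compound 1 `Nc1nccc2c1ncn2[C@H]1C[C@H](O)[C@@H](CO)O1` gives 18% in this assay. Compound 2 `CNc1[nH]ccc2ncnc1-2` gives 18% in this assay, which is no change from compound 1 at the digits shown. Compound 3 `CNc1nccc2c1ncn2C1O[C@H](CO)[C@@H](O)[C@H]1O` gives 8% in this assay, and its gap to compound 1 stays within the scatter of repeated measurements. Thus the three measured numbers do not separate from one another; compound 1 shares its number with compound 2 and lies within the scatter of compound 3, and the inhibition in this assay is level across the three.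

Compound 4 `OC[C@H]1O[C@@H](n2cnc3cnccc32)C[C@@H]1O` is the member still to be measured. It differs from compound 1 in one place: hydrogen in place of amino on an aromatic carbon. The amino group that leaves sits on an aromatic carbon of a six-membered aromatic ring with one nitrogen, part of a fused system of two rings, next to the ring nitrogen. For the measured compounds named here, no pair of measured compounds shows this same change, so the series itself offers no measured step to lean on. Because compound 1 gives 18% and the whole measured spread sits within the scatter, the expected step, a number 5 percentage points lower from compound 1 to compound 4 (within the scatter), is small, none beyond the scatter, with a slight loss of inhibition as the likelier direction if any. Compound 4 is estimated at 13%, with a range from 0% to 28%.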

Compound 4, a percentage reported as inhibition, at one concentration (the size of the read-out at that concentration, not a potency): 6%
For compound 4 the middle estimate is 7 percentage points above the measured one; the range from low to high includes it.
By their numbers in this assay, from the lowest: compounds 4, 3, 1 and 2 (each within the scatter of the next, the first and the last beyond it).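

In this assay, for the compounds shown here, hydrogen in place of amino on an aromatic carbon gives a number 12 percentage points lower from compound 1 to compound 4 (beyond the scatter), the only step that can be read between compounds differing in one place. This position on the shared core, on a six-membered aromatic ring with one nitrogen and next to the ring nitrogen, is therefore not indifferent to what it carries: the amino group goes with more inhibition than hydrogen, although the step is modest and the earlier spread alone could not show it. Nothing in hand bears on the reason for this step.

What the compounds shown leave open is whether another group on this aromatic carbon, such as a hydroxyl, a methoxy group or a chlorine atom, would keep the inhibition seen with compound 1 or match the number of compound 4. Going by these compounds, each number here is also a reading at one concentration, and whether the step would hold as a difference in potency in this assay stays open too.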